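Amide for Glycine on a Shared Indazole-Amine Series

This account rests on a few compounds, and the source may have more. Where it says the series, first, only, none or still open, it means among the compounds named here.

Measured compounds:
compound 1 `O=C(O)CNc1cccc(CNc2cc(C(F)(F)F)cc3[nH]ncc23)c1` — > 100000 nM
compound 2 `O=[N+]([O-])c1ccc2[nH]c(CNc3cc(C(F)(F)F)cc4[nH]ncc34)cc2c1` — > 100000 nM
compound 3 `Cc1ccc(CNc2cc(C(F)(F)F)cc3[nH]ncc23)c([N+](=O)O)c1` — > 100000 nM

In an assay for inhibition of Indoleamine 2,3-dioxygenase 1 (Homo sapiens), with stated times of 10 min and 60 min (on this read-out lower numbers stand for stronger inhibition and higher numbers for weaker inhibition), compound 1 reaches only a limit of the assay, > 100000 nM. The value of compound 2, > 100000 nM, is likewise a limit. Compound 3 gives > 100000 nM, again a limit. Compound 1 therefore stands nowhere in particular among these numbers: all three sit at the same edge, (the limit of > 100000 nM in this assay, at which 3 of the 3 values shown sit), and no measured step between any pair can be drawn.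

The next compound, compound 4 `CNC(=O)c1cccc(CNc2cc(C(F)(F)F)cc3[nH]ncc23)c1`, differs from compound 1 in one place: methylcarbamoyl in place of (carboxymethyl)amino on an aromatic carbon. Since compound 1 gives only a limit in this assay, the size of the step cannot be expected from a measured difference; the most likely outcome is no change beyond the scatter, with the new value again at or near the limit. Compound 4 is thus estimated at 100000 nM, in a range from 30000 nM to 300000 nM, which means an expected step of a number no higher from compound 1 to compound 4 (the limit leaves the size open).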

Compound 4, half-maximal inhibitory concentration: > 100000 nM
Compound 4: a limit, no number; the forecaster's own chance of this, stated with the estimate: 70%; the middle value sits exactly at the limit.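

In this assay compound 4 gives > 100000 nM as a limit of the assay. Among these compounds, compound 1 also stands at a limit, so no step from compound 1 to compound 4 can be read. The compounds shown leave open whether any of them differs in inhibition from the others: the limit of > 100000 nM in this assay, at which 4 of the 4 values shown sit.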